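From butoxy to 3,3,3-trifluoropropoxy

This account rests on a few compounds, and the source may have more. Where it says the series, first, only, none or still open, it means among the compounds named here.

Measured in an ADME assay on Colon (Homo sapiens) for protein binding; a higher number here means a larger unbound share of the compound, a lower number a smaller unbound share:
- compound 1 `CCCOc1nc(OCC(C)(C)O)c(-c2ccc(S(C)(=O)=O)cc2)cc1CO`: 0.066
- compound 2 `CCCCOc1nc(OCC(C)(C)O)c(-c2ccc(S(C)(=O)=O)cc2)cc1CO`: 0.025

Of the two measured compounds, compound 2 has the lower number, at 0.025. Compound 3 `CC(C)(O)COc1nc(OCCC(F)(F)F)c(CO)cc1-c1ccc(S(C)(=O)=O)cc1` has not yet been measured in this assay. It differs from compound 2 by trifluoromethyl in place of ethyl on a saturated chain carbon, two bonds along the chain from an oxygen on an aromatic ring, which also reads as butoxy to 3,3,3-trifluoropropoxy. For the measured compounds named here, only one measured step concerns this chain: a 2.6-fold lower number from compound 1 to compound 2 (0.42 log units; beyond the scatter), with methyl in place of hydrogen on a saturated chain carbon, three bonds along the chain from an oxygen on an aromatic ring. Going by the values given here, it is an imperfect guide, as no measured compound carries fluorine. No shift beyond the scatter is therefore expected. The expected change is a 1.2-fold higher number from compound 2 to compound 3 (0.08 log units; within the scatter). The estimated value for compound 3 is 0.03, with an expected range of 0.013 to 0.07.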

Compound 3, unbound fraction: 0.224
Compound 3: the middle estimate sits 7.5-fold (0.87 log units) below what was measured; the whole stated range lies below it.
By their numbers in this assay, from the lowest: compound 2; then compound 1; then compound 3.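

In this assay, this chain position proved far more sensitive to the change than the earlier compounds had shown: trifluoromethyl in place of ethyl gave a 9.0-fold higher number from compound 2 to compound 3 (0.95 log units; beyond the scatter) and so moved the number further, and in the opposite direction, than the added methyl of a 2.6-fold lower number from compound 1 to compound 2 (0.42 log units; beyond the scatter) had done. Trifluoromethyl in place of methyl gave a 3.4-fold higher number from compound 1 to compound 3 (0.53 log units; beyond the scatter) as well, which places compound 3 beyond the scatter above both compounds with unfluorinated chains, so the rise does not simply undo the effect of chain length. Nothing available bears on why the number rises with this change.

The compounds shown leave open whether the rise requires all three fluorines or would also appear with a single fluorine on the chain. They also leave open whether it would persist on a longer fluorinated chain, or whether a hydroxyl or a nitrile on the same chain would give a similar number.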